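Dienone sulfonamides: methyl to nitrooxy on the sulfonyl aryl

A few compounds are considered here, and "the series" means these few. Any claim that something is new, unique, unknown or untested is made for them only; others in the source may bear on it.

Measured in a functional assay on SMMC-7721 cells (Homo sapiens) for cytotoxicity, read by MTT assay, with a stated time of 24 h; a lower number here means a stronger inhibitor, a higher number a weaker inhibitor:
compound 1 `Cc1ccc(S(=O)(=O)N2C/C(=C\c3ccccc3F)C(=O)/C(=C/c3ccccc3F)C2)cc1` gives 4100 nM
compound 2 `O=C1/C(=C/c2ccccc2F)CN(S(=O)(=O)c2ccc(O[N+](=O)[O-])cc2)C/C1=C\c1ccccc1F` gives 6200 nM
compound 3 `Cc1ccc(S(=O)(=O)N2C/C(=C\c3ccc(F)cc3)C(=O)/C(=C/c3ccc(F)cc3)C2)cc1` gives 5000 nM

The three numbers sit close together and no gap between them is beyond the scatter. From compound 1 to compound 2 the change is nitrooxy in place of methyl on an aromatic carbon, and the step it made in this assay was a 1.5-fold higher number from compound 1 to compound 2 (0.18 log units; within the scatter). Compound 3 and compound 1 hold the same atoms joined differently; the difference between the two cores is not broken down here.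

Compound 4 `O=C1/C(=C/c2ccc(F)cc2)CN(S(=O)(=O)c2ccc(O[N+](=O)[O-])cc2)C/C1=C\c1ccc(F)cc1` is not yet measured in this assay. It differs from compound 3 by nitrooxy in place of methyl on an aromatic carbon, the same change as from compound 1 to compound 2, at the same place. Going by the values given here, the expected step in this assay is a 1.5-fold higher number from compound 3 to compound 4 (0.18 log units; within the scatter), resting on the single earlier instance, a 1.5-fold higher number from compound 1 to compound 2 (0.18 log units; within the scatter). For compound 4 the estimate in this assay is 7500 nM, between 4000 nM and 14000 nM.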

Compound 4, half-maximal inhibitory concentration: 5000 nM
Estimate against measurement, compound 4: 1.5-fold (0.18 log units) above; measured number inside the range.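

In this assay, nitrooxy in place of methyl on the aromatic carbon gives no change at the digits printed from compound 3 to compound 4 (within the scatter). The two steps for this change do not differ on the two cores: the same change on two cores in this assay, a 1.5-fold higher number (0.18 log units; within the scatter) from compound 1 to compound 2 and no change at the digits printed (within the scatter) from compound 3 to compound 4, 1.5-fold (0.18 log units) apart, within the scatter of two such steps. The change therefore carries from one core to the other without a gap beyond the scatter, but with both steps inside the scatter, this does not show that nitrooxy alters the read-out at all, and two pairs cannot show how it would behave on other cores.

Going by these compounds, it remains open how an amine or a carboxylic acid in place of the methyl would read in this assay. Also open, on these data alone, is whether the comparison holds with chlorine or methoxy in place of the fluorine on the outer aromatic rings.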